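The source may hold more compounds than are shown below. What is called first, only, known or untested is meant among the compounds shown, and "the series" means these compounds.

Measured so far:
- compound 1, `O=C1C=C(Nc2ccc(Cl)cc2)CCC1`: in an assay on isolated protein for inhibition of cytochrome c oxidase subunit 2 (Homo sapiens), read by ELISA, with a stated time of 2 min (a lower number here means a stronger inhibitor, a higher number a weaker inhibitor), compound 1 gives 513 nM
- compound 2, `CC(C)(C)OC(=O)N(C1=CC(=O)CCC1)c1ccc(Cl)cc1`: in this assay compound 2 gives 915 nM

Within the data shown here, compound 2 stands highest of the two numbers so far, but its only neighbour is compound 1, and the step of a 1.8-fold higher number from compound 1 to compound 2 (0.25 log units; within the scatter) is within the scatter, so the two compounds cannot be separated on these data.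

The next compound, compound 3, `CC(=O)N(C1=CC(=O)CCC1)c1ccc(Cl)cc1`, keeps the acylated nitrogen of compound 2 and changes only the acyl group: methyl in place of tert-butoxy on a carbonyl carbon.

Among the measured compounds shown here, only one measured step exists, a 1.8-fold higher number from compound 1 to compound 2 (0.25 log units; within the scatter), and it concerns the arrival of the whole tert-butoxycarbonyl group on the nitrogen, not a trimming of that group to acetyl. For the measured compounds named here, it shows that the acyl group on the nitrogen made no difference beyond the scatter, which is the only guidance available for compound 3. On that basis compound 3 is expected to fall close to compound 2, with a step of a 1.1-fold lower number from compound 2 to compound 3 (0.06 log units; within the scatter) that is not expected to exceed the scatter. The estimate for compound 3 in this assay is 800 nM, within a range of 350 nM to 1900 nM.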

Compound 3, half-maximal inhibitory concentration: 367 nM
For compound 3 the middle estimate is 2.2-fold (0.34 log units) above the measured one; low and high end bracket the measured number.
By their numbers in this assay, from the lowest: compounds 3, 1 and 2 (each within the scatter of the next, the first and the last beyond it).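

In this assay, among these compounds, the acyl group on the nitrogen does make a modest difference: trimming tert-butoxycarbonyl to acetyl gives a 2.5-fold lower number from compound 2 to compound 3 (0.40 log units; beyond the scatter) and is the first step beyond the scatter, something that the earlier step of a 1.8-fold higher number from compound 1 to compound 2 (0.25 log units; within the scatter) could not show. Acetyl in place of the hydrogen on the nitrogen gives a 1.4-fold lower number from compound 1 to compound 3 (0.15 log units; within the scatter) and stays within the scatter, so acylating this nitrogen is not shown to shift the number in either case, and compound 1 cannot be separated from compound 2 or from compound 3; only the two acylated compounds can be told apart. Nothing in the available data explains the difference between the two acyl groups.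

Going by these compounds, with only tert-butoxycarbonyl and acetyl on this nitrogen, it remains open how a longer acyl chain, a benzoyl group or an acyl group carrying an amine would read, and whether any of them would separate from compound 1. On these data alone, it is also open whether the change from tert-butoxycarbonyl to acetyl would give a similar step with something other than the chlorine on the aromatic ring.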